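The source may hold more compounds than are shown below. What is called first, only, known or untested is meant among the compounds shown, and "the series" means these compounds.

In a functional assay on OE19 cells (Homo sapiens) for cytotoxicity, read by MTT assay, with a stated time of 48 h (on this read-out higher numbers stand for weaker inhibition and lower numbers for stronger inhibition), compound 1 `CC1(C)S[C@@H]2/C(=C\C(=O)c3ccco3)C(=O)N2[C@H]1C(=O)OC(c1ccccc1)c1ccccc1` gives 54300 nM, and compound 2 `COC(=O)/C=C1\C[C@H]2SC(C)(C)[C@H](C(=O)OC(c3ccccc3)c3ccccc3)N2C1=O` gives 99700 nM; these two values lie within the usual scatter of each other, so neither stands apart. Compound 3 `CC1(C)S[C@@H]2/C(=C\C(=O)c3ccc(F)cc3)C(=O)N2[C@H]1C(=O)OC(c1ccccc1)c1ccccc1` differs from compound 1 in one place: 4-fluorophenyl in place of furan-2-yl on a carbonyl carbon. Within the data shown here, no measured pair shows this change, so nothing in the data points to a direction. The step from compound 1 to compound 3 is expected to be small, a 1.1-fold lower number from compound 1 to compound 3 (0.04 log units; within the scatter), not beyond the scatter. Compound 3 is therefore expected to give about 50000 nM in this assay, within a range from 18000 nM to 140000 nM.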

Compound 3, half-maximal inhibitory concentration: 12100 nM
For compound 3 the middle estimate is 4.1-fold (0.62 log units) above the measured one; measured number below the stated range.
By their numbers in this assay, from the lowest: compound 3; then compounds 1 and 2 (each within the scatter of the next).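

The group on the carbonyl carbon matters: in this assay, 4-fluorophenyl in place of furan-2-yl gives a 4.5-fold lower number from compound 1 to compound 3 (0.65 log units; beyond the scatter), so this position is not indifferent to what sits there. Among these compounds, this is the first change in one place whose size can be read, as the earlier compounds offered no such step. Nothing available explains the step.

Going by these compounds, it remains open whether the step belongs to the fluorine or to the six-membered ring itself, which a plain phenyl on the same carbonyl carbon would separate. On these data alone, how an amine in place of the fluorine would read is equally open.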